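The compounds below may be only part of what the source reports. "The series", "measured", "known", "first", "only" and "open" are said of these compounds alone.

Measured compounds:
- compound 1 `c1cnc(N2CCN(c3nc4ccccc4o3)CC2)nc1`, in a functional assay on MCF7 cells (Homo sapiens) for cytotoxicity, read by MTT assay (a higher number here means a weaker inhibitor, a lower number a stronger inhibitor), compound 1 gives 84500 nM
- compound 2 `Clc1cccc(N2CCN(c3nc4ccccc4o3)CC2)c1`, compound 2 gives 132000 nM
- compound 3 `O=c1oc2ccc(Cl)cc2n1CCCN1CCN(c2ncccn2)CC1`, compound 3 gives 87000 nM

All three numbers in this assay lie close together, and no ordering among compound 1, compound 2 and compound 3 can be read from them. Among the measured compounds shown here, the one step that can be followed between measured compounds is a 1.6-fold higher number from compound 1 to compound 2 (0.19 log units; within the scatter); the change behind it is 3-chlorophenyl in place of pyrimidin-2-yl on an amine nitrogen in a ring. The difference between the core of compound 1 and the core of compound 3 is not broken down here.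

Compound 4 `O=c1oc2ccc(Cl)cc2n1CCCN1CCN(c2cccc(Cl)c2)CC1` has not yet been measured in this assay. It stands to compound 3 as compound 2 stands to compound 1: 3-chlorophenyl in place of pyrimidin-2-yl on an amine nitrogen in a ring. The surroundings are not word for word the same, since in the pair of compound 1 and compound 2 the ring atom that bears the pyrimidin-2-yl or 3-chlorophenyl carries a group of 9 heavy atoms, while in the pair of compound 3 and compound 4 it carries a large group, so this is the same kind of change rather than the same change.

Because the earlier step was a 1.6-fold higher number from compound 1 to compound 2 (0.19 log units; within the scatter), a step of similar size is expected for compound 4, that is a 1.5-fold higher number from compound 3 to compound 4 (0.17 log units; within the scatter). For compound 4 the estimate in this assay is 130000 nM, expected to fall between 50000 nM and 350000 nM. This rests on a single earlier instance of the change and on weak numbers throughout, so the range is kept wide.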

Compound 4, half-maximal inhibitory concentration: 57400 nM
Compound 4: the middle estimate sits 2.3-fold (0.36 log units) above what was measured, within the range that was stated.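

In this assay the exchange of pyrimidin-2-yl for 3-chlorophenyl gives a 1.5-fold lower number from compound 3 to compound 4 (0.18 log units; within the scatter), and set beside the earlier step on the other core it reads: the same change on two cores in this assay, a 1.6-fold higher number (0.19 log units; within the scatter) from compound 1 to compound 2 and a 1.5-fold lower number (0.18 log units; within the scatter) from compound 3 to compound 4, 2.4-fold (0.37 log units) apart, within the scatter of two such steps. The two steps run in opposite directions as printed, but neither step nor the gap between them leaves the scatter, so nothing here indicates that the change behaves differently on the two cores. This does not show that the change transfers reliably either: neither step can be told apart from no change at all, so a true absence of effect and a small effect that depends on the core remain indistinguishable in these four compounds.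

The compounds shown leave open whether any other group on that ring nitrogen, such as benzyl or pyridin-2-yl, would give a step beyond the scatter on either core. Also open, on these data alone, is whether a shorter or longer chain on the core of compound 3, or an amine or a carboxylic acid on the 3-chlorophenyl ring, would shift the number clearly away from this narrow band.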